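Compound 1 to compound 3: a trifluoromethyl step

A few compounds are considered here, and "the series" means these few. Any claim that something is new, unique, unknown or untested is made for them only; others in the source may bear on it.

Going by the values given here, in a physicochemical assay for lipophilicity, at pH 7.4 (a higher number here means a more lipophilic compound, a lower number a more polar compound), compound 1 `CN(C)C(=O)C1CCN(c2cnccc2-n2cccn2)CC1` gives 1.1, the lower of the two numbers measured so far. Compound 2 `Cc1ccn(-c2ccncc2N2CCC(C(=O)N(C)C)CC2)n1` gives 1.5. Compound 3 `CN(C)C(=O)C1CCN(c2cnccc2-n2cc(C(F)(F)F)cn2)CC1` is still unmeasured and differs from compound 1 in one place: trifluoromethyl in place of hydrogen on an aromatic carbon. This is trifluoromethyl in place of hydrogen on an aromatic carbon of a five-membered aromatic ring with 2 nitrogen, two ring bonds from the ring nitrogen and two ring bonds from the ring atom that bears a large group.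

Among the compounds with values here, only one measured step bears on this change: a number 0.40 log units higher from compound 1 to compound 2 (beyond the scatter). That step, methyl in place of hydrogen on an aromatic carbon of the same ring, is modest but beyond the scatter. Within the data shown here, no trifluoromethyl compound has been measured, so the guide is thin. Trifluoromethyl is the bigger group, and a step in the same direction but larger than that one is expected in this assay. The expected step is a number 0.90 log units higher from compound 1 to compound 3 (beyond the scatter). For compound 3 the estimated value is 2, with an expected range of 1.6 to 2.5.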

Compound 3, distribution coefficient: 2.1
Beside the measured number, compound 3's estimate is 0.10 log units below it; measured number inside the range.
By their numbers in this assay, from the lowest: compound 1; then compound 2; then compound 3.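

In this assay, going by these compounds alone, trifluoromethyl in place of hydrogen on an aromatic carbon gives a number 1.00 log units higher from compound 1 to compound 3 (beyond the scatter) in the series, so this change on the five-membered aromatic ring moves the number by more than the one earlier step on that ring, a number 0.40 log units higher from compound 1 to compound 2 (beyond the scatter) for methyl. The series now has two substitutions on this ring, both moving the number the same way from the unsubstituted compound 1, and neither of the two compounds falls within the scatter of compound 1. Nothing measured here accounts for the size of the new step or for its difference from the methyl step.

The compounds shown leave open how the number responds when this same aromatic carbon carries a nitrile, an amine or a carboxylic acid, and whether any such group brings the number lower than that of compound 1, which gives 1.1. They also leave open how much of the difference between the two steps belongs to the group itself, a question that methyl on the aromatic carbon bearing trifluoromethyl in compound 3 would address directly.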